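Moving from Isopropoxy to Benzyloxy on a Shared Core

This account rests on a few compounds, and the source may have more. Where it says the series, first, only, none or still open, it means among the compounds named here.

Measured in a functional assay on thoracic aorta (Rattus norvegicus, strain Wistar), with a stated time of 15 min; on this read-out higher numbers stand for an effect only at larger amounts of compound and lower numbers for an effect already at smaller amounts:
- compound 1 `CC(C)Oc1ccc(Br)cc1C(C)NC(=O)N(C)S(=O)(=O)c1ccccc1`: 32100 nM
- compound 2 `Cc1ccc(S(=O)(=O)N(C)C(=O)NC(C)c2cc(Br)ccc2OC(C)C)cc1`: 34700 nM
- compound 3 `CC(C)Oc1ccc(Br)cc1C(C)NC(=O)NS(=O)(=O)c1ccccc1`: 143000 nM

Compound 1 sits at the low end of these values, level with its nearest neighbour: the data show a 1.1-fold higher number from compound 1 to compound 2 (0.03 log units; within the scatter). Its furthest neighbour is reached with a 4.5-fold higher number from compound 1 to compound 3 (0.65 log units; beyond the scatter).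

Compound 4 `CC(NC(=O)N(C)S(=O)(=O)c1ccccc1)c1cc(Br)ccc1OCc1ccccc1` keeps the core of compound 1 and changes one group: benzyl in place of isopropyl on an oxygen on an aromatic ring. Among the compounds with values here, neither measured step touches that oxygen, and no measured compound carries anything but isopropyl there, so the data give only indirect guidance. The nitrogen step concerns another place and offers little here. The added methyl of compound 2, at 34700 nM, is the only measured gain of carbon, and it stayed within the scatter of compound 1. In this assay, no step beyond the scatter is therefore expected, though with wide uncertainty. The expected result is a 1.1-fold higher number from compound 1 to compound 4 (0.04 log units; within the scatter). For compound 4 the estimated value is 35000 nM, with an expected range from 11000 nM to 110000 nM.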

Compound 4, half-maximal effective concentration: 60300 nM
For compound 4 the middle estimate is 1.7-fold (0.24 log units) below the measured one; measured number inside the range.
By their numbers in this assay, from the lowest: compounds 1, 2 and 4 (each within the scatter of the next); then compound 3.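

In this assay, the oxygen on an aromatic ring now has a measured change of its own: benzyl in place of isopropyl gives a 1.9-fold higher number from compound 1 to compound 4 (0.27 log units; within the scatter) for this single change. A group of 7 heavy atoms with one six-membered aromatic ring of carbon only thus replaces one of 3 heavy atoms with no ring, and the step stays within the scatter, so this read-out does not separate isopropoxy from benzyloxy at this place. Nothing in the data shown accounts for this result.

Open, as far as these compounds go, is whether a methyl, a hydroxyethyl chain or a benzyl carrying a carboxylic acid on this oxygen would also stay within the scatter. Also open, from the compounds shown here alone, is whether benzyl would give the same result with hydrogen in place of methyl on the amide-type nitrogen.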